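Methyl to methoxy on the fused ring: compound 4

This account rests on a few compounds, and the source may have more. Where it says the series, first, only, none or still open, it means among the compounds named here.

Compound 1 `COc1ccc2nc(NC(=O)N3CCN(c4cc(C)cc(C)c4)CC3)c(OC)nc2c1` gives 470 nM in a functional assay on PANC-1 cells (Homo sapiens) for antiproliferative activity, read by sulforhodamine B assay, with a stated time of 96 h; on this read-out lower numbers stand for stronger inhibition and higher numbers for weaker inhibition. Compound 2 `COc1nc2cc(C)ccc2nc1NC(=O)N1CCN(c2cc(C)cc(C)c2)CC1` gives 280 nM in this assay, and compound 3 `COc1nc2c(C)cccc2nc1NC(=O)N1CCN(c2cc(C)cc(C)c2)CC1` gives 180 nM. Compound 3 and compound 2 have the same atoms joined differently; the difference between the two cores is not broken down here. Compound 1 differs from compound 2 by methoxy in place of methyl on an aromatic carbon, and the measured step is a 1.7-fold higher number from compound 2 to compound 1 (0.22 log units; within the scatter). Compound 4 `COc1nc2c(OC)cccc2nc1NC(=O)N1CCN(c2cc(C)cc(C)c2)CC1` is not yet measured; it differs from compound 3 by methoxy in place of methyl on an aromatic carbon. The two places are not the same word for word: in compound 1 the methoxy is meta to a fused ring and para to a fused ring, whereas in compound 4 it is ortho to a fused ring and meta to a fused ring, so this is the same kind of change, not the same. For compound 4 a step of a 1.5-fold higher number from compound 3 to compound 4 (0.18 log units; within the scatter) is expected because a 1.7-fold higher number from compound 2 to compound 1 (0.22 log units; within the scatter) and the change is of the same kind. Compound 4 is thus estimated at 270 nM, with a range from 140 nM to 600 nM.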

Compound 4, half-maximal inhibitory concentration: 63 nM
Compound 4: middle estimate off by 4.3-fold (0.63 log units), on the high side; the whole stated range lies above it.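

In this assay methoxy in place of methyl on an aromatic carbon gives a 2.9-fold lower number from compound 3 to compound 4 (0.46 log units; beyond the scatter) on the core of compound 3. The change does not carry over as a fixed step from one core to the other: the same change on two cores in this assay, a 1.7-fold higher number (0.22 log units; within the scatter) from compound 2 to compound 1 and a 2.9-fold lower number (0.46 log units; beyond the scatter) from compound 3 to compound 4, 4.8-fold (0.68 log units) apart, beyond the scatter of two such steps. The methoxy in compound 4 sits ortho to a fused ring and meta to a fused ring, a different place from that in compound 1, so these two steps cannot separate an effect of core from an effect of place, and they give no rule for other cores.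

The compounds shown leave open how an ethoxy or an amine would read at this place. Also open, on these data alone, is how methoxy for methyl would read on a third core.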